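Swapping Cyclobutyl for Sec-Butyl on a Shared Core

The source may hold more compounds than are shown below. What is called first, only, known or untested is meant among the compounds shown, and "the series" means these compounds.

Of the compounds shown here, three built on one shared core have been measured in an assay on isolated protein for displacement of a labelled ligand from melanin-concentrating hormone receptor 1 (Homo sapiens); on this read-out lower numbers stand for stronger inhibition and higher numbers for weaker inhibition. Compound 1 `CCCc1cc(N)c2cc(NC(=O)c3ccc(-c4ccc(Cl)cc4)cc3)ccc2n1` gives 0.7 nM. Compound 2 `Nc1cc(C2CCC2)nc2ccc(NC(=O)/C=C/c3ccc(C(F)(F)F)cc3)cc12` gives 2 nM. Compound 3 `CCCc1cc(NC)c2cc(NC(=O)/C=C/c3ccc(C(F)(F)F)cc3)ccc2n1` gives 1.5 nM. Among these three numbers, compound 2 stands highest, which on this read-out means the weakest inhibition of the set. Its nearest neighbour is compound 3, whose number is lower but by a margin that lies within the usual scatter, so no order between compound 2 and compound 3 can be claimed. The gap to compound 1 is larger and lies beyond the scatter.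

Compound 4 `CCC(C)c1cc(N)c2cc(NC(=O)/C=C/c3ccc(C(F)(F)F)cc3)ccc2n1` has not yet been measured. It differs from compound 2 in one place: sec-butyl in place of cyclobutyl on an aromatic carbon. The leaving group and the entering group are alike in size, with one difference being that the cyclobutyl closes a ring while the sec-butyl does not. For the measured compounds named here, no measured pair in this set tests such a change, so there is nothing to lean on beyond the structures themselves. The step of no change at the digits printed from compound 2 to compound 4 (within the scatter) is therefore expected to stay within the scatter, in no clear direction. Compound 4 is estimated to give 2 nM in this assay, within a range from 0.8 nM to 5 nM.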

Compound 4, half-maximal inhibitory concentration: 0.3 nM
Compound 4: the middle estimate sits 6.7-fold (0.82 log units) above what was measured; the measured number lies below the stated range.
By their numbers in this assay, from the lowest: compound 4; then compound 1; then compounds 3 and 2 (each within the scatter of the next).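

For the compounds shown here, at this position, on an aromatic carbon next to the ring nitrogen, replacing cyclobutyl with sec-butyl in this assay gives a 6.7-fold lower number from compound 2 to compound 4 (0.82 log units; beyond the scatter), so the read-out responds clearly to a swap that the earlier compounds did not test. Both groups have 4 heavy atoms, all carbon, and neither has a hydrogen-bond donor or acceptor, so these counts do not separate them; what does differ is that cyclobutyl contains a four-membered ring and sec-butyl has no ring. Nothing available here accounts for the lower number with sec-butyl, so the structural difference can be described but not offered as an explanation.

This single pair cannot show whether opening the ring or the particular branched shape of sec-butyl matters more, and an n-butyl chain, an isopropyl group or a cyclopentyl ring at the same position on the same core would help to separate those possibilities. Going by these compounds alone, it also leaves open whether the same swap would give a step of similar size on a compound with a different amide side chain, such as the one in compound 1.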